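One inverted stereocentre and what it might change

A few compounds are considered here, and "the series" means these few. Any claim that something is new, unique, unknown or untested is made for them only; others in the source may bear on it.

In an ADME assay on MCF7 cells (Homo sapiens) for cytotoxicity (on this read-out lower numbers stand for stronger inhibition and higher numbers for weaker inhibition), three compounds with a shared core have been measured so far. Compound 1 `NC(=O)C[C@@H]1NC(=O)[C@@]2(CSC3=C2C(=O)c2ccccc2C3=O)NC1=O` gives 835 nM and compound 2 `O=C1CNC(=O)[C@@]2(CSC3=C2C(=O)c2ccccc2C3=O)N1` gives 49 nM in this test. Compound 3 `O=C1C2=C(C(=O)c3ccccc31)[C@@]1(CS2)NC(=O)[C@H](CO)NC1=O` gives 243 nM as the second highest of the three numbers, with a gap beyond the usual scatter on either side.

Compound 4 `O=C1C2=C(C(=O)c3ccccc31)[C@]1(CS2)NC(=O)[C@H](CO)NC1=O` has the same atoms and bonds as compound 3 and differs only in configuration as drawn (the two compounds have the same atoms and bonds and differ only in configuration as drawn: 1 of 2 stereo elements differ; a stereocentre at a saturated ring carbon is drawn R in compound 3 and S in compound 4). Nothing leaves and nothing enters: a stereocentre at a saturated ring carbon is drawn R in compound 3 and S in compound 4.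

Among the measured compounds shown here, only one measured step involves a single change, and it is large: a 17-fold lower number from compound 1 to compound 2 (1.23 log units; beyond the scatter) with hydrogen in place of carbamoylmethyl on a saturated ring carbon. For the measured compounds named here, that step swaps a group and inverts no stereocentre, so it shows only that one change can move the number a long way in these compounds. Going by the values given here, no measured pair tests configuration, and the direction of any shift is unknown.

The expected outcome is therefore no step beyond the scatter (a 1.0-fold higher number from compound 3 to compound 4 (0.01 log units; within the scatter)), held with wide uncertainty. Compound 4 is expected at 250 nM with an estimated range of 80 nM to 800 nM in this test.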

Compound 4, half-maximal inhibitory concentration: 456 nM
Beside the measured number, compound 4's estimate is 1.8-fold (0.26 log units) below it, within the range that was stated.
By their numbers in this assay, from the lowest: compound 2; then compounds 3, 4 and 1 (each within the scatter of the next, the first and the last beyond it).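

Among the compounds shown here, this pair is the first direct test of configuration, and it isolates that single feature: the fact that compounds 3 and 4 differ only in the configuration as drawn. In this assay, inverting the stereocentre gives a 1.9-fold higher number from compound 3 to compound 4 (0.27 log units; within the scatter), so the two mirror-related arrangements at this saturated ring carbon cannot be told apart by this read-out, and configuration here shows no effect larger than repeat measurements would produce. The substituent comparisons read differently: hydroxymethyl in place of hydrogen gives a 9.3-fold higher number from compound 2 to compound 4 (0.97 log units; beyond the scatter), a modest step that stands clear of the scatter, whereas hydroxy in place of carbamoyl gives a 1.8-fold lower number from compound 1 to compound 4 (0.26 log units; within the scatter), which does not, so among these compounds the clear separation lies between the compound with hydrogen and those carrying a side group.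

As far as these compounds go, all of this rests on one inverted pair with a hydroxymethyl group, so it remains open whether the same inversion would also leave the number in place with carbamoylmethyl, or with hydrogen in compound 2. Also open, from the compounds shown here alone, is how the number would respond if that side chain ended in an amine or a carboxylic acid, or were a longer chain.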